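The source may report more compounds than this note shows. Statements on the series, on what has been measured and on what is new or still open speak of the compounds shown alone.

Compound 1 `CC(=O)Oc1ccc(-c2ccc(F)cc2F)cc1C(=O)O` — 0%
Compound 2 `O=C(Oc1ccc(-c2ccc(F)cc2F)cc1C(=O)O)c1ccccc1` — 7.97%

In a functional assay on the whole organism (strain Kunming) for inhibition, with Mus musculus as the target, in the writhing test, at a dose of 40 mg/kg by the oral route (on this read-out lower numbers stand for less inhibition and higher numbers for more inhibition at the one dose given (going by the name of the read-out)), compound 1 gives 0%, the lowest of the two numbers. Compound 2 gives 7.97%, and the step of a number 8 percentage points higher from compound 1 to compound 2 (within the scatter) lies within the scatter. Compound 3 `CNC(=O)c1cc(-c2ccc(F)cc2F)ccc1OC(C)=O` differs from compound 1 by methylamino in place of hydroxy on a carbonyl carbon. Going by the values given here, no measured step touches this change: the one step known, a number 8 percentage points higher from compound 1 to compound 2 (within the scatter), replaces methyl by phenyl on a carbonyl carbon and leaves the carboxy untouched, so nothing here speaks for a move beyond the scatter. The step of a number 8 percentage points higher from compound 1 to compound 3 (within the scatter) is therefore expected to stay small. Compound 3 is estimated at 8%, between 0% and 30%.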

Compound 3, a percentage reported as inhibition, in the whole organism at one dose (the size of the read-out at that dose, not a potency): 29.9%
Beside the measured number, compound 3's estimate is 21.9 percentage points below it, and the stated range covers the measured number.
By their numbers in this assay, from the lowest: compounds 1 and 2 (each within the scatter of the next); then compound 3.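

In this assay, the carboxy to methylcarbamoyl change at this carbonyl carbon moves the read-out beyond the scatter (a number 29.9 percentage points higher from compound 1 to compound 3 (beyond the scatter)). The only earlier step (a number 8 percentage points higher from compound 1 to compound 2 (within the scatter)) was made at the other carbonyl carbon and stayed within the scatter, so this position is the first shown to respond. Nothing available bears on the cause of this step.

The compounds shown leave open whether the methyl on the amide nitrogen matters, which a plain amino or an ethylamino group at this place would address. Also open, as far as these compounds go, is whether phenyl in place of methyl on the other carbonyl carbon behaves the same once methylamino is present.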